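The compounds below may be only part of what the source reports. "The series", "measured", "known", "first", "only" and "open" are said of these compounds alone.

In an ADME assay on blood (Homo sapiens) for pharmacokinetics (a lower number here means that the compound disappears faster, a higher number that the compound lasts longer), compound 3 `COC(=O)CCNC(=O)[C@@H]1O[P@@](=O)(OCOC(=O)c2ccns2)OCC1(C)C` gives only a limit, < 0.16 h, so its exact number is not known. Compound 1 `COC(=O)CCNC(=O)[C@@H]1O[P@](=O)(OCOC(=O)c2ccnn2C)OCC1(C)C` likewise gives a limit, < 0.16 h. Compound 2 `CCc1cc(C(=O)OCO[P@@]2(=O)OCC(C)(C)[C@H](C(=O)NCCC(=O)OC)O2)n(C)n1` also gives a limit, >= 0.97 h. For the measured compounds named here, every value shown is therefore a limit, and compound 3 sits at the limit of < 0.16 h in this assay, at which 2 of the 3 values shown sit, while only one compound reaches (the limit of >= 0.97 h in this assay, at which 1 of the 3 values shown sits). Going by the values given here, the single measured step that swaps this ring, an at least 6.0-fold lower number from compound 2 to compound 3 (0.78 log units; beyond the scatter), went downward. Compound 4 `COC(=O)CCNC(=O)[C@@H]1O[P@@](=O)(OCOC(=O)c2ccnn2C)OCC1(C)C` differs from compound 3 by 1-methyl-1H-pyrazol-5-yl in place of 1,2-thiazol-5-yl on a carbonyl carbon. Compound 1 carries this same entering ring and stays at the lower limit. Compound 4 is therefore expected to change little, the estimated step being an at least 1.2-fold higher number from compound 3 to compound 4 (0.09 log units; that floor lies within the scatter), giving an estimated 0.2 h with a range of 0.08 h to 0.9 h.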

Compound 4, half-life: > 1 h
Compound 4 gave a limit, no number; the forecaster's own chance of this, stated with the estimate: 55%; at least 5.0-fold (0.69 log units) between middle value and limit.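

In this assay, the swap on the carbonyl carbon gives an at least 6.2-fold higher number from compound 3 to compound 4 (0.79 log units; beyond the scatter), so 1-methyl-1H-pyrazol-5-yl alone does not keep a compound short-lived. The stereocentre at phosphorus counts as well, with an at least 6.2-fold higher number from compound 1 to compound 4 (0.79 log units; beyond the scatter), and this step can be laid on configuration alone: the fact that compounds 1 and 4 differ only in the configuration as drawn. The step from compound 2 to compound 4 cannot be read, as both values are limits.

Still open, from the compounds shown here alone, is how 1,2-thiazol-5-yl behaves with the phosphorus configuration of compound 1. Also open, going by these compounds, is what an amine on the carbonyl carbon, in place of 1-methyl-1H-pyrazol-5-yl, would give.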